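The source may hold more compounds than are shown below. What is called first, only, known or untested is meant among the compounds shown, and "the series" means these compounds.

This account follows the exchange at the thioether sulfur in a short series of chromone-derived thioethers, measured in a functional assay on SW480 cells (Homo sapiens) for cytotoxicity, read by MTT assay, with a stated time of 72 h; a higher number here means a weaker inhibitor, a lower number a stronger inhibitor. Compound 1 `Cc1nnc(SCc2cc(=O)c3ccccc3o2)o1` gives > 25000 nM, which is a limit of the assay rather than a number. Compound 2 `Cc1ccc2oc(CSc3nnc(C)s3)cc(=O)c2c1` likewise gives > 25000 nM, again a limit. Compound 3 `Cc1ccc2oc(CSc3nnc(N)s3)cc(=O)c2c1` gives > 25000 nM, once more a limit. Compound 3 therefore stands at the limit of this assay together with the other two compounds, as summed up by the limit of > 25000 nM in this assay, at which 3 of the 3 values shown sit. Among the measured compounds shown here, the one step that can be traced between measured compounds, a step that the two limits leave unreadable from compound 2 to compound 3, is an amino in place of methyl on an aromatic carbon. Both ends of that step sit at the limit, and its size cannot be read.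

Compound 4 `Cc1ccc2oc(CSc3nnc(C)o3)cc(=O)c2c1` has not yet been measured. It differs from compound 3 by 5-methyl-1,3,4-oxadiazol-2-yl in place of 5-amino-1,3,4-thiadiazol-2-yl on a sulfur; in words, 5-methyl-1,3,4-oxadiazol-2-yl in place of 5-amino-1,3,4-thiadiazol-2-yl on a sulfur. For the measured compounds named here, no measured step covers this exchange, and the only step available, from compound 2 to compound 3, is unreadable. Nothing among the three values suggests a readable potency, so compound 4 is expected to sit again at the limit, with an estimated step that the limit leaves unreadable from compound 3 to compound 4 from compound 3. The estimate for compound 4 in this assay is 40000 nM, with a range from 15000 nM to 200000 nM.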

Compound 4, half-maximal inhibitory concentration: > 25000 nM
Compound 4: only a limit was reported; the forecaster's own chance of this, stated with the estimate: 85%; the middle value does not contradict the limit.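

In this assay compound 4 gives > 25000 nM, which is a limit of the assay and not a number. Among the compounds shown here, no step from compound 1, compound 2 or compound 3 to compound 4 can be read: the limit of > 25000 nM in this assay, at which 4 of the 4 values shown sit. The compounds shown leave open which group on the sulfur, if any, would give a readable potency.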